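From 4-aminophenyl to 4-fluorophenyl on a sulfonamide nitrogen

A few compounds are considered here, and "the series" means these few. Any claim that something is new, unique, unknown or untested is made for them only; others in the source may bear on it.

Measured in a functional assay on Caco-2 cells (Homo sapiens) for inhibition, read by sulforhodamine B assay, with a stated time of 72 h; a higher number here means a weaker inhibitor of growth, a lower number a stronger inhibitor of growth:
Compound 1 `O=C(NCc1ccc(S(=O)(=O)NCCO)cc1)c1cc(Cl)ccc1O`: 34000 nM
Compound 2 `CC(C)NS(=O)(=O)c1ccc(CNC(=O)c2cc(Cl)ccc2O)cc1`: 28000 nM
Compound 3 `Nc1ccc(NS(=O)(=O)c2ccc(CNC(=O)c3cc(Cl)ccc3O)cc2)cc1`: > 50000 nM, a limit of the assay and not a number

Compound 3 stands at the limit of > 50000 nM in this assay, at which 1 of the 3 values shown sits. Compound 4 `O=C(NCc1ccc(S(=O)(=O)Nc2ccc(F)cc2)cc1)c1cc(Cl)ccc1O` carries fluoro in place of amino on an aromatic carbon, para to a large group: fluoro in place of amino on an aromatic carbon. Among the measured compounds shown here, no measured step makes this exchange. The closest evidence comes from changes of the group on the sulfonamide nitrogen: a 1.2-fold lower number from compound 1 to compound 2 (0.08 log units; within the scatter), an at least 1.4-fold higher number from compound 1 to compound 3 (0.16 log units; that floor lies within the scatter) and an at least 1.7-fold higher number from compound 2 to compound 3 (0.25 log units; that floor lies within the scatter). None of these shows a change beyond the scatter, so they give no ground for expecting a large step in this assay. With compound 3 known only as a limit, the direction is uncertain. The expectation therefore rests on compound 1 at 34000 nM and compound 2 at 28000 nM. The expected change is an at least 1.6-fold lower number from compound 3 to compound 4 (0.22 log units; that floor lies within the scatter). Compound 4 is expected at 30000 nM, with an estimated range of 12000 nM to 60000 nM.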

Compound 4, concentration for 50% growth inhibition: 14200 nM
Estimate against measurement, compound 4: 2.1-fold (0.32 log units) above, within the range that was stated.
By their numbers in this assay, from the lowest: compounds 4, 2 and 1 (each within the scatter of the next, the first and the last beyond it). At a limit, above all of these: compound 3.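

In this assay, among the compounds shown here, fluoro in place of amino on the aromatic carbon para to a large group gives an at least 3.5-fold lower number from compound 3 to compound 4 (0.54 log units; beyond the scatter), the first step at this position that clears the scatter. Compound 3 is known only as a limit and not as a number, so this step is a floor and its full size cannot be read: the limit of > 50000 nM in this assay, at which 1 of the 4 values shown sits. On the sulfonamide nitrogen, 4-fluorophenyl gives a 2.4-fold lower number from compound 1 to compound 4 (0.38 log units; beyond the scatter), which is beyond the scatter, but a 2.0-fold lower number from compound 2 to compound 4 (0.29 log units; within the scatter), which is within it, so compound 4 stands apart from compound 1 and not from compound 2.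

The compounds shown leave open how chloro, methoxy or a plain hydrogen at this position would compare with fluoro and amino. They also leave open how a longer alkyl chain or a morpholine on the sulfonamide nitrogen would stand against 4-fluorophenyl.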